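This account rests on a few compounds, and the source may have more. Where it says the series, first, only, none or still open, it means among the compounds named here.

Measured in a functional assay on HCT-116 cells (Homo sapiens) for antiproliferative activity, read by MTT assay, with a stated time of 48 h; a higher number here means a weaker inhibitor, a lower number a stronger inhibitor:
- Compound 1 `CCOc1cc(-c2ccc3ccn(C)c3c2)cn2c(-c3cc(OC)c(OC)c(OC)c3)nnc12`: 291 nM
- Compound 2 `CCOc1cc(-c2ccc3c(ccn3C)c2)cn2c(-c3cc(OC)c(OC)c(OC)c3)nnc12`: 228 nM

Among the compounds with values here, only two compounds have been measured so far, and they cannot be told apart. Compound 2, at 228 nM, has the lower of the two numbers in this assay, but its gap to compound 1 lies within the scatter, so neither can be ranked above the other.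

The next compound is compound 3 `COc1cc(-c2nnc3c(OC4COC4)cc(-c4ccc5c(ccn5C)c4)cn23)cc(OC)c1OC`. It differs from compound 2 by oxetan-3-yl in place of ethyl on an oxygen on an aromatic ring, with oxetan-3-yl in place of ethyl on an oxygen on an aromatic ring. The ethoxy thus becomes (oxetan-3-yl)oxy.

Within the data shown here, the one measured step offers little guidance. It is a 1.3-fold lower number from compound 1 to compound 2 (0.11 log units; within the scatter), which lies within the scatter and concerns a different part of the molecule, leaving the ethoxy untouched. Among the measured compounds shown here, no measured compound varies the group on this oxygen, so the size of the coming step cannot be read from the data. With no evidence for a direction, no shift beyond the scatter is expected in this assay, though the uncertainty is wide.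

The estimated step is a 1.3-fold higher number from compound 2 to compound 3 (0.12 log units; within the scatter). For compound 3 the expected value is 300 nM, with an estimated range from 90 nM to 1000 nM.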

Compound 3, half-maximal inhibitory concentration: 1290 nM
The estimate for compound 3 lay 4.3-fold (0.63 log units) below the measured number, outside the stated range (above it).
By their numbers in this assay, from the lowest: compounds 2 and 1 (each within the scatter of the next); then compound 3.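

In this assay, the group on this oxygen proves to be a place where one change moves the number beyond the scatter: oxetan-3-yl in place of ethyl gives a 5.7-fold higher number from compound 2 to compound 3 (0.75 log units; beyond the scatter) and so a weaker inhibitor. Within the data shown here, the only earlier step, a 1.3-fold lower number from compound 1 to compound 2 (0.11 log units; within the scatter), lay within the scatter and left the ethoxy untouched, so it gave no sign of how much this position could matter. No measurement available here speaks to why the number rises on going from ethoxy to (oxetan-3-yl)oxy.

From the compounds shown here alone, it remains open whether the step follows the four-membered ring or the ring oxygen, which cyclobutyl or 2-methoxyethyl on the same oxygen could help to separate, and whether methyl or a longer chain such as propyl would stay close to ethyl. Also open, going by these compounds, is whether the same exchange would have a similar size with the 1-methyl-1H-indol-6-yl group of compound 1 in place of the 1-methyl-1H-indol-5-yl group of compound 2.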